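A few compounds are considered here, and "the series" means these few. Any claim that something is new, unique, unknown or untested is made for them only; others in the source may bear on it.

Three compounds with a shared core, an amide bearing an amine-containing chain, have been tested in a functional assay on the whole organism (strain AKR) for inhibition, with Rattus norvegicus as the target, read by paw edema, at a dose of 0.2 mmol/kg by the intraperitoneal route, in the presence of a further agent that is not named here; on this read-out lower numbers stand for less inhibition and higher numbers for more inhibition at the one dose given (going by the name of the read-out). Compound 1, with the structure `CN(C)CC(=O)Nc1nccs1`, gives 28.4% in this assay. Compound 2, with the structure `COc1ccc(-c2csc(NC(=O)CCN3CCCC3)n2)cc1`, gives 56.2%, and compound 3, with the structure `O=C(CCN1CCCC1)Nc1nccs1`, gives 64.1%. Compound 1 thus stands lowest of the three numbers: its nearest neighbour is compound 2, whose number is higher by a gap beyond the usual scatter, and the furthest is compound 3, whose number is higher still, also beyond the scatter.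

Compound 4, with the structure `Cc1csc(NC(=O)CN(C)C)n1`, is not yet measured. It differs from compound 1 by one change, (methyl in place of hydrogen on an aromatic carbon). Among the compounds with values here, no pair of measured compounds differs by this change alone, so there is nothing in the measured numbers that speaks for a rise or a fall. The step of a number 3.6 percentage points higher from compound 1 to compound 4 (within the scatter) is therefore expected to stay within the scatter. For compound 4 the estimate is 32%, within a range from 12% to 55%.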

Compound 4, a percentage reported as inhibition, in the whole organism at one dose (the size of the read-out at that dose, not a potency): 37.6%
The estimate for compound 4 lay 5.6 percentage points below the measured number; measured number inside the range.
By their numbers in this assay, from the lowest: compounds 1 and 4 (each within the scatter of the next); then compounds 2 and 3 (each within the scatter of the next).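

Within the data shown here, this is the first pair of compounds that differ in one place. In this assay, methyl in place of hydrogen on an aromatic carbon, next to the ring nitrogen and two ring bonds from the ring sulfur, gives a number 9.2 percentage points higher from compound 1 to compound 4 (within the scatter). The read-out therefore does not separate the two compounds, and this position carries a methyl without a measurable change in the inhibition at this one dose. Nothing at hand explains this outcome or says what the methyl does in the animal.

This single pair leaves open whether a chlorine atom, an ethyl group or a carboxylic acid at the same position would also leave the number within the scatter. It also leaves open what the same methyl would do on the chain of compound 3.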